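Compound 3: from ring amide to free acid

This account rests on a few compounds, and the source may have more. Where it says the series, first, only, none or still open, it means among the compounds named here.

Measured in a functional assay with Canis familiaris (Canis lupus familiaris) as the target, in the presence of a further agent that is not named here; on this read-out higher numbers stand for weaker inhibition and lower numbers for stronger inhibition:
- compound 1 `CC(C)[C@H](NC(=O)[C@H](CC(=O)O)NC(=O)CCCOc1ccc(C(=N)N)cc1)C(=O)N1CCOCC1`: 140 nM
- compound 2 `CC(C)[C@H](NC(=O)[C@H](CC(=O)O)NC(=O)CCCOc1ccc(C(=N)N)cc1)C(=O)N1CCS(=O)(=O)CC1`: 110 nM

Compound 2, at 110 nM, stands level with compound 1 within the usual scatter. Compound 3 `CC(C)[C@H](NC(=O)[C@H](CC(=O)O)NC(=O)CCCOc1ccc(C(=N)N)cc1)C(=O)O` has a different end: hydroxy in place of 1,1-dioxothiomorpholin-4-yl on a carbonyl carbon. In words, this is hydroxy in place of 1,1-dioxothiomorpholin-4-yl on a carbonyl carbon, so the ring is lost altogether. Among the measured compounds shown here, only one measured step bears on this, a 1.3-fold lower number from compound 1 to compound 2 (0.10 log units; within the scatter), and it stayed within the scatter. For the measured compounds named here, that step swaps one ring for another, however, and no measured compound lacks the ring, so it gives no direction for the new change. In this assay no shift beyond the scatter is therefore expected, though with wide uncertainty. The expected step is a 1.2-fold higher number from compound 2 to compound 3 (0.07 log units; within the scatter). Compound 3 is estimated at 130 nM, with an expected range of 45 nM to 400 nM.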

Compound 3, half-maximal inhibitory concentration: 380 nM
Compound 3: middle estimate off by 2.9-fold (0.47 log units), on the low side; the range from low to high includes it.
By their numbers in this assay, from the lowest: compounds 2 and 1 (each within the scatter of the next); then compound 3.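

In this assay, replacing the ring amide with a free carboxy group on this carbonyl carbon gives a 3.5-fold higher number from compound 2 to compound 3 (0.54 log units; beyond the scatter) and a 2.7-fold higher number from compound 1 to compound 3 (0.43 log units; beyond the scatter), so this end of the molecule does affect the read-out, though only modestly. The swap between the two rings stayed within the scatter, whereas losing the ring altogether gives weaker inhibition, so at this position, among these three compounds, having a ring amide counts for more than which of the two rings it is. No supporting data here explain this difference.

From the compounds shown here alone, it remains open whether the ring itself matters, or whether replacing the carboxy group is enough. A dimethylamide or a methyl ester on the same carbonyl carbon would help to separate these two possibilities.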